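A few compounds are considered here, and "the series" means these few. Any claim that something is new, unique, unknown or untested is made for them only; others in the source may bear on it.

Working notes on the series, all read in an ADME assay on IMR-90 cells (Homo sapiens) for antiproliferative activity, read by MTT assay, with a stated time of 72 h; on this read-out higher numbers stand for weaker inhibition and lower numbers for stronger inhibition. Compound 1 `O=C1C=C(N2CCN(c3ccccc3Cl)CC2)C(=O)c2ccccc21` gives > 50000 nM, which is a limit of the assay and not a number. Among the measured compounds shown here, compound 2 `O=C1C=C(N2CCN(c3ccccc3Cl)CC2)C(=O)c2c(O)cccc21` gives 16900 nM, the only true number so far. For the measured compounds named here, the one measured step is an at least 2.9-fold lower number from compound 1 to compound 2 (0.47 log units; beyond the scatter), with hydroxy in place of hydrogen on an aromatic carbon. For compound 1 this step rests on (the limit of > 50000 nM in this assay, at which 1 of the 2 values shown sits), so its size is bounded on one side only.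

Compound 3 `Cc1ccccc1N1CCN(C2=CC(=O)c3cccc(O)c3C2=O)CC1` differs from compound 2 as follows: methyl in place of chloro on an aromatic carbon. This is methyl in place of chloro on an aromatic carbon, ortho to a large group. Going by the values given here, no measured step replaces chloro, so the hydroxy step gives no size or direction for this change. The expectation in this assay therefore stays anchored on compound 2 at 16900 nM, with no step beyond the scatter. The expected step is a 1.1-fold higher number from compound 2 to compound 3 (0.03 log units; within the scatter). The estimate for compound 3 is 18000 nM, with an expected range from 7000 nM to 45000 nM.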

Compound 3, half-maximal inhibitory concentration: > 50000 nM
Compound 3 was reported as a limit; the forecaster's own chance of this, stated with the estimate: 12%; middle value at least 2.7-fold (0.44 log units) from the limit.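

In this assay, among the compounds shown here, the change from 2-chlorophenyl to 2-methylphenyl is the first measured change at this place, on an aromatic carbon ortho to a large group, and it gives an at least 2.9-fold higher number from compound 2 to compound 3 (0.47 log units; beyond the scatter). The earlier step, an at least 2.9-fold lower number from compound 1 to compound 2 (0.47 log units; beyond the scatter), showed only what the hydroxy does with chloro held in place; this result shows that, with the hydroxy held in place, the group at this other position also decides whether a true number is read at all, so the hydroxy alone does not secure one. Methyl in place of chloro thus reads as a real change in this series rather than a silent swap of one small group for another, though its size is bounded on one side only: the limit of > 50000 nM in this assay, at which 2 of the 3 values shown sit.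

The compounds shown leave open how a fluoro, a methoxy or an amine at this place would read, and whether chloro is the only group there that gives a true number. They also leave open whether the difference between chloro and methyl holds on the core of compound 1, without the hydroxy, where the chloro compound already stands at a limit of the assay.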